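From phenoxy to benzoyl(methyl)amino on a shared core

A few compounds are considered here, and "the series" means these few. Any claim that something is new, unique, unknown or untested is made for them only; others in the source may bear on it.

In a physicochemical assay for solubility, read by LC-MS, in phosphate buffer, with a stated time of 24 h, at pH 7.4 (a lower number here means a less soluble compound, a higher number a more soluble compound), compound 1 (`Fc1ccc2c(c1CNc1ncc(Oc3ccccc3)c3nncn13)CCO2`) gives 8000 nM and stands as the higher of the two measured compounds. Compound 2 (`CN(C)C(=O)c1cc(-c2cnc(NCc3c(F)ccc4c3CCO4)c3cn[nH]c(=O)c23)n(C)n1`) gives 3000 nM as a lower number, beyond the scatter. Compound 3 (`CN(C(=O)c1ccccc1)c1cnc(NCc2c(F)ccc3c2CCO3)n2cnnc12`) keeps the core of compound 1 but carries benzoyl(methyl)amino in place of phenoxy on an aromatic carbon. For the measured compounds named here, no measured pair shows this change, so no step beyond the scatter is expected in this assay here. The expectation is a 1.6-fold lower number from compound 1 to compound 3 (0.20 log units; within the scatter) as a slight fall at most. Compound 3 is estimated at 5000 nM (1200 nM to 20000 nM).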

Compound 3, solubility: 280000 nM
Compound 3: the middle estimate sits 56-fold (1.75 log units) below what was measured; measured number above the stated range.
By their numbers in this assay, from the lowest: compound 2; then compound 1; then compound 3.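

On the shared core, this place on an aromatic carbon turns out to matter greatly in this assay: benzoyl(methyl)amino in place of phenoxy brings a 35-fold higher number from compound 1 to compound 3 (1.54 log units; beyond the scatter), so the two groups are not interchangeable here. Both groups hold one six-membered aromatic ring of carbon only, with the same counts of hydrogen-bond donors and acceptors and no net charge, so these counts do not tell them apart. Nothing measured here gives a reason for the step.

Going by these compounds, it remains open whether the benzoyl part or the methyl on the nitrogen carries the step. A plain amine or an acetyl(methyl)amino group at this place could test that.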